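Swapping Trifluoromethyl for Methoxy on a Benzyl Arm

The source may hold more compounds than are shown below. What is called first, only, known or untested is meant among the compounds shown, and "the series" means these compounds.

Compound 1 `O=C(CCC1=CCN(Cc2ccc(C(F)(F)F)cc2)C1=O)NO` is a hydroxamic acid tested in a functional assay on MDA-MB-231 cells (Homo sapiens) for antiproliferative activity (a higher number here means a weaker inhibitor of growth, a lower number a stronger inhibitor of growth), where compound 1 gives 3070 nM. Within the data shown here, that is the highest of the three numbers measured so far. Compound 3 `COc1cccc(CCCN2CC=C(CCC(=O)NO)C2=O)c1` gives 1880 nM, which lies within the usual scatter of the value of compound 1, so the two cannot be ordered. Compound 2 `O=C(CCC1=CCN(Cc2cccc(C(F)(F)F)c2)C1=O)NO` gives 220 nM, a gap beyond the scatter, so compound 2 is clearly the stronger growth inhibitor of the pair. Compound 4 `COc1ccc(CN2CC=C(CCC(=O)NO)C2=O)cc1` has not yet been measured; it differs from compound 1 by methoxy in place of trifluoromethyl on an aromatic carbon. Among the measured compounds shown here, no two measured compounds differ in exactly one place, so no measured step guides this change. The step of a 1.2-fold lower number from compound 1 to compound 4 (0.09 log units; within the scatter) is expected to stay within the scatter, with no clear direction. Compound 4 is therefore expected to give about 2500 nM, most likely between 700 nM and 9000 nM.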

Compound 4, concentration for 50% growth inhibition: 1630 nM
For compound 4 the middle estimate is 1.5-fold (0.19 log units) above the measured one; the range from low to high includes it.
By their numbers in this assay, from the lowest: compound 2; then compounds 4, 3 and 1 (each within the scatter of the next).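

Among these compounds, this is the first single change that can be read: in this assay, methoxy in place of trifluoromethyl, on an aromatic carbon para to a large group, gives a 1.9-fold lower number from compound 1 to compound 4 (0.27 log units; within the scatter). At this position, then, exchanging these two groups does not separate the compounds, and neither can be ranked above the other. Nothing measured here offers an explanation for this result. On these data alone, whether an amine or a carboxylic acid on this same carbon would also leave the compound within the scatter of compound 1 remains open.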